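The compounds below may be only part of what the source reports. "The series", "measured", "known", "first", "only" and "open" are said of these compounds alone.

Measured in a functional assay on HT-29 cells (Homo sapiens) for antiproliferative activity, read by sulforhodamine B assay, with a stated time of 48 h; on this read-out lower numbers stand for stronger inhibition and higher numbers for weaker inhibition:

- compound 1, `CCCN1CCN(c2ccc(S(=O)(=O)Oc3ccc(OC)cc3)cc2)C1=O`: in this assay compound 1 gives 16000 nM
- compound 2, `CCCN1CCN(c2ccc(S(=O)(=O)Oc3ccc(F)cc3)cc2)C1=O`: in this assay compound 2 gives 23000 nM
- compound 3, `CCCCN1CCN(c2ccc(S(=O)(=O)Oc3cccc(OC)c3)cc2)C1=O`: in this assay compound 3 gives 13000 nM

Compounds 1 and 2 differ in one place: fluoro in place of methoxy on an aromatic carbon. The step is a 1.4-fold higher number from compound 1 to compound 2 (0.16 log units; within the scatter), so the two values are not separated in this assay.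

Compound 3 stands apart from compound 1 by more than one change; the difference between the two cores is not broken down here. Its value sits within the scatter of both compound 1 and compound 2.

Compound 4, `CCCCN1CCN(c2ccc(S(=O)(=O)Oc3cccc(F)c3)cc2)C1=O`, is not yet measured. Relative to compound 3 it carries fluoro in place of methoxy on an aromatic carbon. The place differs from the change in compounds 1 and 2: there the fluoro is para to a large group, here it is meta to a large group, so this is the same kind of change, not the same change.

The expectation for compound 4 rests on compound 1 and compound 2, where the step was a 1.4-fold higher number from compound 1 to compound 2 (0.16 log units; within the scatter); a step of similar size, a 1.4-fold higher number from compound 3 to compound 4 (0.14 log units; within the scatter), is expected. For compound 4 in this assay the estimate is 18000 nM, expected to lie between 9000 nM and 36000 nM.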

Compound 4, half-maximal inhibitory concentration: 76000 nM
Beside the measured number, compound 4's estimate is 4.2-fold (0.63 log units) below it; measured number above the stated range.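

In this assay the new step is a 5.8-fold higher number from compound 3 to compound 4 (0.77 log units; beyond the scatter), so on the core of compound 3, fluoro in place of methoxy weakens inhibition beyond the scatter. Set beside the earlier step, the same change does not carry from one core to the other at one size: the same change on two cores in this assay, a 1.4-fold higher number (0.16 log units; within the scatter) from compound 1 to compound 2 and a 5.8-fold higher number (0.77 log units; beyond the scatter) from compound 3 to compound 4, 4.1-fold (0.61 log units) apart, beyond the scatter of two such steps. This shows that the step read on one core is a poor guide to the step on the other, but it does not show what sets the two apart, since the pairs differ both in the chain, propyl in compound 1 and butyl in compound 3, and in the place of the changed group.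

Among the compounds shown, no pair changes the chain or the place alone, so it stays open which of the two goes with the larger step. Going by these compounds, it also stays open whether the step is specific to fluoro, which a chloro, methyl or hydroxyl group in the same place on the core of compound 3 could test.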